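From Compound 2 to Compound 4: One Ring Group Exchanged

The compounds below may be only part of what the source reports. "The series", "measured", "known", "first", "only" and "open" are said of these compounds alone.

Measured in an assay on HEK293 cells for inhibition of Voltage-dependent T-type calcium channel subunit alpha-1G (Homo sapiens), read by fluorescence, tested at 10 uM; a lower number here means less inhibition, a higher number more inhibition at the concentration tested (going by the name of the read-out):
compound 1 `CCCc1nc(-c2ccccc2)c(CNCCN2CCN(c3ccc(Cl)cc3)CC2)o1` gives 55.8%
compound 2 `CCCc1nc(-c2ccccc2)c(CNCCCN2CCN(c3cccc(OC)c3)CC2)o1` gives 36.4%
compound 3 `CCCc1nc(-c2ccccc2)c(CNCCN2CCN(c3cccc(C)c3C)CC2)o1` gives 66.7%

Compound 2 stands lowest of the three, beyond the scatter below both compound 1 and compound 3. Compound 4 `CCCc1nc(-c2ccccc2)c(CNCCCN2CCN(c3ccccc3C)CC2)o1` is not yet measured and differs from compound 2 in one place: 2-methylphenyl in place of 3-methoxyphenyl on an amine nitrogen in a ring. For the measured compounds named here, the only measured step that touches the same ring nitrogen is a number 10.9 percentage points higher from compound 1 to compound 3 (beyond the scatter), where exchanging the group on that nitrogen raised inhibition modestly. Those are different groups, so the guidance is loose. A small rise in this assay is therefore expected for compound 4, roughly a number 8.6 percentage points higher from compound 2 to compound 4 (within the scatter), which may or may not exceed the scatter. Compound 4 is estimated at 45%, between 28% and 62%.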

Compound 4, a percentage reported as inhibition, at one concentration (the size of the read-out at that concentration, not a potency): 54.5%
Compound 4: the middle estimate sits 9.5 percentage points below what was measured; low and high end bracket the measured number.
By their numbers in this assay, from the lowest: compound 2; then compounds 4 and 1 (each within the scatter of the next); then compound 3.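

In this assay, the group on this ring nitrogen also matters with the longer chain: the change to 2-methylphenyl gives a number 18.1 percentage points higher from compound 2 to compound 4 (beyond the scatter). For the compounds shown here, the only earlier step at this nitrogen, a number 10.9 percentage points higher from compound 1 to compound 3 (beyond the scatter), involved a shorter chain and different groups. No measurement shown here gives a cause for the rise.

The compounds shown do not separate the effect of losing the methoxy group from that of adding the methyl group. From the compounds shown here alone, how an unsubstituted phenyl or a trifluoromethyl group on that ring would behave with this chain also remains open.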